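A few compounds are considered here, and "the series" means these few. Any claim that something is new, unique, unknown or untested is made for them only; others in the source may bear on it.

Measured compounds in a functional assay on the whole organism for inhibition, with Rattus norvegicus as the target, read by paw edema, with stated times of 30 min and 1 h, at a dose of 10 mg/kg by the oral route; on this read-out higher numbers stand for more inhibition at the one dose given (going by the name of the read-out) and lower numbers for less inhibition:
compound 1 `O=C1N=C(C2C(=O)c3ccccc3C2=O)CC(c2ccccc2)N1` gives 20%
compound 2 `COc1ccc(C2CC(C3C(=O)c4ccccc4C3=O)=NC(=O)N2)cc1` gives 22%
compound 3 `O=C1N=C(C2C(=O)c3ccccc3C2=O)CC(/C=C/c2ccccc2)N1` gives 17%

Compound 3 sits at the low end of the three numbers, but neither gap separates it from the others: a number 3 percentage points lower from compound 1 to compound 3 (within the scatter) and a number 5 percentage points lower from compound 2 to compound 3 (within the scatter) are both within the scatter, as is a number 2 percentage points higher from compound 1 to compound 2 (within the scatter). On the numbers shown, nothing in this series has yet moved this assay beyond the scatter.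

Compound 4 `O=C1N=C(C2C(=O)c3ccccc3C2=O)CC(c2ccccc2O)N1` is reached from compound 3 by the change (2-hydroxyphenyl in place of 2-phenylethenyl on a saturated ring carbon). For the measured compounds named here, the steps that bear on it are the two into compound 3, a number 3 percentage points lower from compound 1 to compound 3 (within the scatter) and a number 5 percentage points lower from compound 2 to compound 3 (within the scatter), which show that exchanging phenyl or 4-methoxyphenyl for 2-phenylethenyl at this ring carbon leaves this assay within the scatter. Going back to a phenyl ring is therefore not expected to shift the read-out. Going by the values given here, no step with a 2-hydroxyphenyl group exists, and the only oxygen-bearing aromatic ring measured, the methoxy of compound 2, gave a number 2 percentage points higher from compound 1 to compound 2 (within the scatter), within the scatter. No step beyond the scatter is therefore expected for a number 3 percentage points higher from compound 3 to compound 4 (within the scatter).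

Compound 4 is estimated at 20% in this assay, with an expected range of 8% to 32%.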

Compound 4, a percentage reported as inhibition, in the whole organism at one dose (the size of the read-out at that dose, not a potency): 24%
The estimate for compound 4 lay 4 percentage points below the measured number, within the range that was stated.
By their numbers in this assay, from the lowest: compounds 3, 1, 2 and 4 (each within the scatter of the next).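

In this assay, the 2-hydroxyphenyl group on the saturated ring carbon next to the ring nitrogen brings a hydrogen-bond donor and a hydrogen-bond acceptor that 2-phenylethenyl lacks, yet all three steps into compound 4 stay within the scatter (step one: a number 7 percentage points higher from compound 3 to compound 4 (within the scatter); step two: a number 2 percentage points higher from compound 2 to compound 4 (within the scatter); step three: a number 4 percentage points higher from compound 1 to compound 4 (within the scatter)). Hydroxy on the aromatic ring therefore joins methoxy as a change that leaves this read-out within the scatter, and across the four compounds shown, no change at this position separates one compound from another, with none going against that pattern. No measurement on hand accounts for these numbers.

Going by these compounds, it remains open whether any group at this ring carbon can move the read-out beyond the scatter, for example an amine or a carboxylic acid on the aromatic ring, or a plain alkyl chain in place of that ring. Since all the values come from one oral dose, they also leave open how the inhibition of paw edema would change with dose for any of these compounds.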